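The source may report more compounds than this note shows. Statements on the series, on what has been measured and on what is new or still open speak of the compounds shown alone.

Series notes. Compound 1, `NS(=O)(=O)CC(=O)NCCSc1nonc1/C(=N/O)Nc1cccc(C(F)F)c1`, gives 17 nM in an assay for inhibition of Indoleamine 2,3-dioxygenase 1 (Homo sapiens), read by fluorescence, with a stated time of 24 h; a lower number here means a stronger inhibitor, a higher number a weaker inhibitor. Compound 2, `N#Cc1cccc(N/C(=N\O)c2nonc2SCCNC(=O)CS(N)(=O)=O)c1`, gives 44 nM in this assay. Compound 3, `CS(=O)(=O)NCCSc1nonc1/C(=N/O)Nc1ccc(F)c(Br)c1`, gives 9.3 nM in this assay. The lowest of the three numbers stands with compound 3, though compound 1 is within the scatter of it; compound 2 is the furthest away, beyond the scatter. Among the compounds with values here, the single measured step, a 2.6-fold higher number from compound 1 to compound 2 (0.41 log units; beyond the scatter), concerns the substituent on the aromatic ring and not the chain end that changes in the next compound.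

Within the data shown here, compound 4, `NS(=O)(=O)CC(=O)NCCSc1nonc1/C(=N/O)Nc1ccc(F)c(Br)c1`, is the next compound. (sulfamoylmethyl)carbonyl in place of methylsulfonyl on an amine nitrogen No measured pair isolates this change: compounds 1 and 2 both carry the (sulfamoylmethyl)carbonyl group and compound 3 the methylsulfonyl, but the aromatic ring differs among them as well, so their numbers speak to the chain end only indirectly. With that chain end, compound 1 gives 17 nM and compound 2 gives 44 nM, both in the same low range as compound 3, so the expectation for this assay is a step that stays within the scatter, in either direction. Compound 4 is therefore expected to give 12 nM, with a range from 5 nM to 30 nM. The expected step of a 1.3-fold higher number from compound 3 to compound 4 (0.11 log units; within the scatter) lies within the scatter.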

Compound 4, half-maximal inhibitory concentration: 12 nM
Estimate against measurement, compound 4: no gap at the digits printed; measured number inside the range.
By their numbers in this assay, from the lowest: compounds 3, 4 and 1 (each within the scatter of the next); then compound 2.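

Within the data shown here, the step of a 1.3-fold higher number from compound 3 to compound 4 (0.11 log units; within the scatter) is the first to isolate the group on the amine nitrogen, with the 3-bromo-4-fluorophenyl group held constant: in this assay, (sulfamoylmethyl)carbonyl and methylsulfonyl cannot be told apart at this position, despite the larger group entering. Compound 4 also extends the set carrying (sulfamoylmethyl)carbonyl to three aromatic groups, and here the aromatic group does separate the compounds: a 3.7-fold lower number from compound 2 to compound 4 (0.56 log units; beyond the scatter) lies beyond the scatter, whereas a 1.4-fold lower number from compound 1 to compound 4 (0.15 log units; within the scatter) lies within it, leaving 3-bromo-4-fluorophenyl and 3-(difluoromethyl)phenyl indistinguishable and 3-cyanophenyl apart from both. No supporting evidence accompanies these numbers, so they give no account of either result.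

From the compounds shown here alone, the indifference to the group on the amine nitrogen rests on a single pair, so it remains open whether it also holds with 3-cyanophenyl or 3-(difluoromethyl)phenyl on the other side of the molecule. Also open, going by these compounds, is how this position responds to a carboxylic acid or a primary amine at the end of the chain, or to a longer chain before the sulfamoyl group.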